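One stereocentre from compound 3 to compound 4

This account rests on a few compounds, and the source may have more. Where it says the series, first, only, none or still open, it means among the compounds named here.

In a functional assay on the whole organism (Cricetulus griseus) with Cricetinae gen. sp. as the target (a lower number here means that less compound is needed, a higher number that more compound is needed for the effect), compound 1 (`CCCC[C@](C)(OC)[C@@H](O)/C=C/C1[C@H](O)CC(=O)[C@@H]1C/C=C\CCCC(=O)OC`) gives > 1 mg/kg, which is a limit. Compound 2 (`CCCC[C@](C)(OC)[C@H](O)/C=C/C1[C@H](O)CC(=O)[C@@H]1C/C=C\CCCC(=O)OC`) gives > 1 mg/kg, again a limit. Compound 3 (`CCCC[C@@](C)(OC)[C@H](O)/C=C/C1[C@H](O)CC(=O)[C@@H]1C/C=C\CCCC(=O)OC`) gives > 1 mg/kg, also a limit and the only position known for it. Among the measured compounds shown here, the series so far therefore rests on (the limit of > 1 mg/kg in this assay, at which 3 of the 3 values shown sit), and no measured number exists yet.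

Compound 4 (`CCCC[C@@](C)(OC)[C@@H](O)/C=C/C1[C@H](O)CC(=O)[C@@H]1C/C=C\CCCC(=O)OC`) differs from compound 3 by the two compounds have the same atoms and bonds; at least one stereo element is drawn with a configuration in one of them and without one in the other: 1 of 7 stereo elements differ; a stereocentre at a saturated chain carbon is drawn R in compound 3 and S in compound 4. The two have the same atoms and bonds, with a stereocentre at a saturated chain carbon drawn R in compound 3 and S in compound 4.

For the measured compounds named here, three measured steps bear on this change: a step that the two limits leave unreadable from compound 1 to compound 2, a step that the two limits leave unreadable from compound 2 to compound 3 and a step that the two limits leave unreadable from compound 1 to compound 3. None has a readable size, so they give no measure for a further change of configuration, and neither size nor direction can be carried over from them. All three compounds remain at the limit, so another limit is the likeliest result, although a measured number remains possible.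

The estimated step is a step that the limit leaves unreadable from compound 3 to compound 4, with no direction that the data can fix. For compound 4 the expected value is 2 mg/kg, with an estimated range of 0.5 mg/kg to 10 mg/kg.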

Compound 4, dose for half-maximal effect: > 1 mg/kg
Compound 4 gave a limit, no number (the forecaster's own chance of this, stated with the estimate: 65%); the middle value does not contradict the limit.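

In this assay compound 4 gives > 1 mg/kg, which is a limit. No step from compound 1, compound 2 or compound 3 to compound 4 can be read, and the series still rests on: the limit of > 1 mg/kg in this assay, at which 4 of the 4 values shown sit.

The compounds shown leave open how far apart these four stereoisomers lie in this assay, and whether any configuration drawn here reaches a measured dose.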